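A few compounds are considered here, and "the series" means these few. Any claim that something is new, unique, unknown or untested is made for them only; others in the source may bear on it.

Measured compounds, values in an assay on isolated protein for inhibition of leukotriene B4 receptor 1 (Homo sapiens), tested at 10 uM; a higher number here means more inhibition at the concentration tested (going by the name of the read-out), a lower number less inhibition:

compound 1 `CCc1cc(C(C)=O)c(O)cc1OCCCCCCC#N`: compound 1 gives 103%
compound 2 `CCc1cc(C(C)=O)c(O)cc1OCCCCC(C)(C)C#N`: compound 2 gives 79%
compound 3 `CCc1cc(C(C)=O)c(O)cc1OCCCCCC(C)(C)C#N`: compound 3 gives 85%

Compound 3 stands second highest of the three numbers. Its nearest neighbour is compound 2, with a number 6 percentage points higher from compound 2 to compound 3 (within the scatter), a gap within the scatter. Its furthest is compound 1, with a number 18 percentage points lower from compound 1 to compound 3 (beyond the scatter), a modest step beyond the scatter; compound 1 carries no branching at the chain end, and the step from compound 1 to compound 2, a number 24 percentage points lower from compound 1 to compound 2 (beyond the scatter), points the same way.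

Compound 4 `CCc1cc(C(C)=O)c(O)cc1OCCCCCCCC(C)(C)C#N` differs from compound 3 as follows: 3-cyano-3-methylbutyl in place of 1-cyano-1-methylethyl on a saturated chain carbon, five bonds along the chain from an oxygen on an aromatic ring. The branching with the nitrile is kept; only the chain between the aromatic oxygen and that end is longer, from five heavy atoms to seven in the group that changes. For the measured compounds named here, the only measured step that bears on this is the chain extension from compound 2 to compound 3, which stayed within the scatter. The steps from compound 1 concern branching, not length, so they do not bear directly.

Within the scatter, no step beyond the scatter is therefore expected for compound 4, a number 1 percentage points lower from compound 3 to compound 4 (within the scatter). Compound 4 is estimated at 84%, with an expected range from 64% to 100%.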

Compound 4, a percentage reported as inhibition, at one concentration (the size of the read-out at that concentration, not a potency): 66%
The estimate for compound 4 lay 18 percentage points above the measured number, within the range that was stated.
By their numbers in this assay, from the lowest: compound 4; then compounds 2 and 3 (each within the scatter of the next); then compound 1.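

In this assay, 3-cyano-3-methylbutyl in place of 1-cyano-1-methylethyl, five bonds along the chain from an oxygen on an aromatic ring, gives a number 19 percentage points lower from compound 3 to compound 4 (beyond the scatter), so with the branched nitrile end kept, chain length does register here, which a number 6 percentage points higher from compound 2 to compound 3 (within the scatter) had not shown. The longer chain also separates from the shortest branched one, a number 13 percentage points lower from compound 2 to compound 4 (beyond the scatter), and the widest gap in the set is a number 37 percentage points lower from compound 1 to compound 4 (beyond the scatter), which leaves compound 4 lowest, beyond the scatter of each of the others. Nothing at hand accounts for this fall.
Open, as far as these compounds go, is whether a still longer chain with the same branched end lowers the number further, and how an unbranched chain of the same length as in compound 4 compares with it. Also open, from the compounds shown here alone, is whether a carboxylic acid in place of the nitrile holds up at either chain length.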